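The source may report more compounds than this note shows. Statements on the series, on what has been measured and on what is new or still open speak of the compounds shown alone.

Three compounds have so far been run in a functional assay on A549 cells (Homo sapiens) for inhibition, read by MTT assay, with a stated time of 72 h, tested at 20 uM; on this read-out lower numbers stand for less inhibition and higher numbers for more inhibition at the one concentration tested (going by the name of the read-out). Compound 1 `CN(c1ccc(Oc2ncnc3ccsc23)cc1)c1nccc(N2CCc3ccccc3C2)n1` gives 69.9%, compound 2 `CN(c1ccc(Oc2ncnc3sccc23)cc1)c1nccc(N2CCCCC2)n1` gives 51.9%, and compound 3 `c1ccc2c(c1)CCN(c1ccnc(Nc3ccc(Oc4ncnc5sccc45)cc3)n1)C2` gives 34%, the lowest of the three; its gap to compound 2 and its larger gap to compound 1 both lie beyond the usual scatter. Compound 4 `CN(c1ccc(Oc2ncnc3sccc23)cc1)c1nccc(N2CCc3ccccc3C2)n1` has not yet been measured. It differs from compound 3 in one place: methyl in place of hydrogen on a nitrogen on an aromatic ring. The two measured compounds that carry a methyl on that nitrogen, compound 1 and compound 2, both stand beyond the scatter above compound 3, so in this assay a rise is expected, estimated as a number 23 percentage points higher from compound 3 to compound 4 (beyond the scatter). Compound 4 is expected to give about 57%, with a range from 38% to 76%.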

Compound 4, a percentage reported as inhibition, at one concentration (the size of the read-out at that concentration, not a potency): 68.4%
The estimate for compound 4 lay 11.4 percentage points below the measured number; measured number inside the range.
By their numbers in this assay, from the lowest: compound 3; then compound 2; then compounds 4 and 1 (each within the scatter of the next).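

In this assay, methyl in place of hydrogen on a nitrogen on an aromatic ring now has a single-change comparison, giving (a number 34.4 percentage points higher from compound 3 to compound 4 (beyond the scatter)). With that methyl in place, 1,2,3,4-tetrahydroisoquinolin-2-yl in place of piperidin-1-yl gives (a number 16.5 percentage points higher from compound 2 to compound 4 (beyond the scatter)), while exchanging the two groups of 9 heavy atoms on the oxygen gives (a number 1.5 percentage points lower from compound 1 to compound 4 (within the scatter)). No measurement here bears on the reason for these steps. Open, going by these compounds, is whether ethyl or a longer chain on that nitrogen would give a comparable step, and whether a morpholine in place of the 1,2,3,4-tetrahydroisoquinolin-2-yl group would keep the number.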